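From methoxy to dimethylamino on the amide side chain

A few compounds are considered here, and "the series" means these few. Any claim that something is new, unique, unknown or untested is made for them only; others in the source may bear on it.

Compound 1 `COc1ccc(C(=O)c2ccc(OC)c3c2C=CC(C)(C)O3)c(NC(=O)CBr)c1`: 2150 nM
Compound 2 `C=C(c1cc(OC)c(OC)c(OC)c1)c1ccc(OC)c(O)c1NC(C)=O`: 170 nM
Compound 3 `C=C(c1cc(OC)c(OC)c(OC)c1)c1ccc(OC)c(O)c1NC(=O)COC`: 450 nM

All three numbers come from a functional assay on A2780 cells (Homo sapiens) for antiproliferative activity, read by MTT assay, with a stated time of 48 h; a lower number here means a stronger inhibitor, a higher number a weaker inhibitor. Compound 3, at 450 nM, is the second highest of the three, with compound 2 lower and compound 1 higher.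

The next molecule, compound 4 `C=C(c1cc(OC)c(OC)c(OC)c1)c1ccc(OC)c(O)c1NC(=O)CN(C)C`, has dimethylamino in place of methoxy on a saturated chain carbon bound to a carbonyl carbon. For the measured compounds named here, only one measured step touches this carbon: a 2.6-fold higher number from compound 2 to compound 3 (0.42 log units; beyond the scatter), where methoxy took the place of hydrogen. That modest step shows that this place can shift the number, but it involves no dimethylamino and so gives no firm direction. A change of similar or smaller size is therefore a reasonable expectation in this assay, with a slight lean upward.

The expected change is a 1.2-fold higher number from compound 3 to compound 4 (0.09 log units; within the scatter), which would not stand out from the scatter. For compound 4 the estimated value is 550 nM, with an expected range from 180 nM to 1600 nM.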

Compound 4, half-maximal inhibitory concentration: 90 nM
The estimate for compound 4 lay 6.1-fold (0.79 log units) above the measured number; measured number outside the range, below it.
By their numbers in this assay, from the lowest: compounds 4 and 2 (each within the scatter of the next); then compound 3; then compound 1.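

In this assay, the saturated chain carbon bound to the carbonyl carbon can move the number in either direction, depending on the group it carries: dimethylamino in place of methoxy gives a 5.0-fold lower number from compound 3 to compound 4 (0.70 log units; beyond the scatter) and so runs opposite to the step that brought methoxy in. Dimethylamino in place of hydrogen gives a 1.9-fold lower number from compound 2 to compound 4 (0.28 log units; within the scatter) and so leaves the two numbers indistinguishable, which means this group does not carry the penalty seen with methoxy. No supporting measurement here explains why methoxy and dimethylamino behave differently at this carbon.

On the shared core, this carbon carries only hydrogen, methoxy or dimethylamino in the compounds shown. As far as these compounds go, it remains open whether another amine, such as morpholine or a primary amine, a carboxylic acid, or a longer chain ending in dimethylamino would match compound 4 or fall back towards compound 3.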